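Removing the methyl from the methoxy group

The source may hold more compounds than are shown below. What is called first, only, known or untested is meant among the compounds shown, and "the series" means these compounds.

Compound 3 `CCCCCCCCS(=O)(=O)Nc1cc(-c2ccccc2OC)ccc1C(=O)O` gives 16100 nM in an assay on mitochondria (strain BALB/c) for inhibition of glycerol-3-phosphate acyltransferase 1, mitochondrial (Mus musculus), read by scintillation counting, with a stated time of 10 min; on this read-out lower numbers stand for stronger inhibition and higher numbers for weaker inhibition. Compound 1 `CCCCCCCCS(=O)(=O)Nc1cc(-c2ccccc2Cl)ccc1C(=O)O` gives 26900 nM and compound 2 `CCCCCCCCS(=O)(=O)Nc1cc(-c2ccccc2-c2ccccc2)ccc1C(=O)O` gives 17100 nM in this assay; the steps of a 1.7-fold lower number from compound 1 to compound 3 (0.22 log units; within the scatter) and a 1.1-fold lower number from compound 2 to compound 3 (0.03 log units; within the scatter) leave compound 3 with the lowest number of the three without setting it apart from the others. Compound 4 `CCCCCCCCS(=O)(=O)Nc1cc(-c2ccccc2O)ccc1C(=O)O` carries hydrogen in place of methyl on an oxygen on an aromatic ring. Within the data shown here, none of the measured steps, including a 1.6-fold lower number from compound 1 to compound 2 (0.20 log units; within the scatter), touches this oxygen; all three swap the group on the aromatic carbon, and all stay within the scatter. Among the measured compounds shown here, with no direct precedent and only flat steps nearby, compound 4 is expected to show no change beyond the scatter, a step of a 1.0-fold lower number from compound 3 to compound 4 (0.00 log units; within the scatter). The estimate for compound 4 in this assay is 16000 nM, with a range from 5000 nM to 50000 nM.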

Compound 4, half-maximal inhibitory concentration: 63100 nM
The estimate for compound 4 lay 3.9-fold (0.60 log units) below the measured number; measured number above the stated range.
By their numbers in this assay, from the lowest: compounds 3, 2 and 1 (each within the scatter of the next); then compound 4.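

Unlike chloro, phenyl and methoxy, which stay within the scatter of one another, hydroxy at this position does shift the number: swapping the methyl on the oxygen for hydrogen gives a clear change (a 3.9-fold higher number from compound 3 to compound 4 (0.59 log units; beyond the scatter)). Hydroxy also separates from phenyl (a 3.7-fold higher number from compound 2 to compound 4 (0.57 log units; beyond the scatter)) and from chloro (a 2.3-fold higher number from compound 1 to compound 4 (0.37 log units; beyond the scatter)), which makes compound 4 the weakest inhibitor of the four. No measurement here explains this loss.

As far as these compounds go, whether it is specific to hydroxy stays open, as an amine or an ethoxy group at this place would be needed to tell.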